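Tert-Butyl on the Cyclohexyl Amide: Solubility Outlook

The source may report more compounds than this note shows. Statements on the series, on what has been measured and on what is new or still open speak of the compounds shown alone.

Of the compounds shown here, two built on the shared core have been measured in a physicochemical assay for solubility, read by HPLC; on this read-out higher numbers stand for higher solubility and lower numbers for lower solubility. Compound 1 `O=C(c1ccc(F)cc1)N1CCN(c2nc(=O)c3cc(C(F)(F)F)cc([N+](=O)[O-])c3s2)CC1` gives 1.69 ug/mL. Going by the values given here, compound 2 `O=C(C1CCCCC1)N1CCN(c2nc(=O)c3cc(C(F)(F)F)cc([N+](=O)[O-])c3s2)CC1` gives 3.24 ug/mL, the higher of the two numbers as recorded, although the only measured step, a 1.9-fold higher number from compound 1 to compound 2 (0.28 log units; within the scatter), lies within the scatter, so the two values cannot truly be ranked. Compound 3 `CC(C)(C)C1CCC(C(=O)N2CCN(c3nc(=O)c4cc(C(F)(F)F)cc([N+](=O)[O-])c4s3)CC2)CC1` has not yet been measured. It differs from compound 2 by tert-butyl in place of hydrogen on a saturated ring carbon. Among the compounds with values here, no measured step speaks directly to this change: a 1.9-fold higher number from compound 1 to compound 2 (0.28 log units; within the scatter) exchanged the whole group on the carbonyl carbon rather than adding a substituent to a saturated ring carbon, and it was itself within the scatter. The expectation for compound 3 therefore rests on the structural change alone, without a measured precedent in this series. Compound 3 is estimated to come in somewhat lower, at 1.2 ug/mL, with a range from 0.4 ug/mL to 3.5 ug/mL. That estimate corresponds to an expected step of a 2.7-fold lower number from compound 2 to compound 3 (0.43 log units; beyond the scatter), modest and uncertain given the thin basis.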

Compound 3, solubility: < 0.1 ug/mL
Compound 3 was reported as a limit (the forecaster's own chance of this, stated with the estimate: 10%); middle value at least 12-fold (1.07 log units) away from the limit.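

Tert-butyl in place of hydrogen on a saturated ring carbon, three ring bonds from the ring atom that bears a large group, gives an at least 32-fold lower number from compound 2 to compound 3 (1.51 log units; beyond the scatter) and is the first step in this series to lie beyond the scatter, so the read-out does not stay flat when this ring carbon is substituted. The change from 4-fluorophenyl to 4-(tert-butyl)cyclohexyl on the carbonyl carbon likewise gives an at least 16-fold lower number from compound 1 to compound 3 (1.22 log units; beyond the scatter) while the exchange of 4-fluorophenyl for cyclohexyl on that carbon stayed within the scatter, so among these three compounds the large steps are the two that bring in tert-butyl. Compound 3 is reported as a limit of this assay and not as a number: the limit of < 0.1 ug/mL in this assay, at which 1 of the 3 values shown sits.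

The compounds shown leave open whether methyl or ethyl on the same ring carbon would already give a step of this kind, or whether it takes the full tert-butyl group. They also leave open how an amine or a hydroxyl group at that ring carbon would read in this assay on this shared core.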